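Bromo in Place of Nitro: Expected Cytotoxicity Outcome

The source may hold more compounds than are shown below. What is called first, only, known or untested is meant among the compounds shown, and "the series" means these compounds.

Two measured compounds share one core and differ only in the group carried on one aromatic ring. Compound 1 `O=C(COc1cccc2ccccc12)N/N=C/c1ccc(Br)cc1` carries a bromo group there. Compound 2 `O=C(COc1cccc2ccccc12)N/N=C/c1cccc([N+](=O)[O-])c1` carries a nitro group in its place. Both were tested in an ADME assay on HEL cells (Homo sapiens) for cytotoxicity; a higher number here means that more compound is tolerated, a lower number that less compound is tolerated. For compound 1 the result is a limit of the assay rather than a number, > 100 ug/mL (the limit of > 100 ug/mL in this assay, at which 1 of the 2 values shown sits). For compound 2 the result is also a limit rather than a number, >= 20 ug/mL (the limit of >= 20 ug/mL in this assay, at which 1 of the 2 values shown sits). Within the data shown here, compound 2 therefore stands at a limit and cannot be placed precisely; the one other value shown is a limit too, so no step between measured compounds can be computed.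

Compound 3 `O=C(COc1cccc2ccccc12)N/N=C/c1cccc(Br)c1` has not yet been measured. It differs from compound 2 by bromo in place of nitro on an aromatic carbon. The expected step is a step that the limit leaves unreadable from compound 2 to compound 3, with tolerance expected to stay the same or rise, not to fall beyond the scatter. Compound 3 is estimated to give about 100 ug/mL, within a range from 40 ug/mL to 200 ug/mL.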

Compound 3, minimum cytotoxic concentration: 100 ug/mL
The estimate for compound 3 equals the measured number at the digits printed; the measured number falls inside the stated range.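

In this assay compound 3 gives 100 ug/mL, the first result in this set that is a number and not a limit, so a bromo group meta to a large group now has a fixed reading on this scale. Setting 3-bromophenyl in place of 4-bromophenyl gives a number no higher from compound 1 to compound 3 (the limit leaves the size open), which shows a direction that cannot be called a rise but no measured size. The size of that step and of the step for bromo in place of nitro cannot be read, and compound 2 remains a limit: the limit of >= 20 ug/mL in this assay, at which 1 of the 3 values shown sits.

The compounds shown leave open how far tolerance would move if an amine, a carboxylic acid or a methoxy group stood at this same place instead of bromo. Also open, from the compounds shown here alone, is whether exact numbers for compound 1 and compound 2 would fall within the usual scatter of compound 3, which would settle whether moving the bromo, or exchanging it for nitro, makes any real difference in this assay.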